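Difluorophenyl replaces biphenyl ether in compound 4

A few compounds are considered here, and "the series" means these few. Any claim that something is new, unique, unknown or untested is made for them only; others in the source may bear on it.

Compound 1, `CC(C)[C@H](NC(=O)COc1cccc2ccccc12)C(=O)N[C@@H](CC(=O)O)C(=O)COc1ccc(-c2ccccc2)cc1`, measured in a functional assay on Jurkat cells (Homo sapiens) (on this read-out lower numbers stand for stronger inhibition and higher numbers for weaker inhibition), gives 87900 nM. Of the numbers shown in this assay, compound 1 gives the highest. Compound 3, `CC(C)[C@H](NC(=O)COc1cccc2ccccc12)C(=O)N[C@@H](CC(=O)O)C(=O)COc1ccc(F)cc1F`, gives 33200 nM in this assay. Compound 2, `CC(C)[C@H](NC(=O)COc1cccc2ccccc12)C(=O)N[C@@H](CC(=O)O)C(=O)COc1ccc(C(F)(F)F)cc1`, gives only a limit in this assay, > 100000 nM, so no number is known for it. Within the data shown here, the step of a 2.6-fold lower number from compound 1 to compound 3 (0.42 log units; beyond the scatter) is the one measured change of the same kind, and it lowered the number; the step of an at least 3.0-fold lower number from compound 2 to compound 3 (0.47 log units; beyond the scatter) points the same way, though it rests on a limit, (the limit of > 100000 nM in this assay, at which 1 of the 3 values shown sits). Compound 4, `CC(C)[C@H](NC(=O)COc1cccc2ccccc12)C(=O)N[C@@H](CC(=O)O)C(=O)COc1cc(F)cc(F)c1`, differs from compound 1 in one place: 3,5-difluorophenyl in place of 4-phenylphenyl on an oxygen on a saturated carbon. Among the measured compounds shown here, this change resembles the one from compound 1 to compound 3, since a difluorophenyl again replaces the 4-phenylphenyl, only with a 3,5-difluorophenyl instead of a 2,4-difluorophenyl. For the measured compounds named here, an expected step of a 2.0-fold lower number from compound 1 to compound 4 (0.29 log units; within the scatter) therefore seems reasonable for compound 4, somewhat smaller than that to compound 3 because only one such step, a 2.6-fold lower number from compound 1 to compound 3 (0.42 log units; beyond the scatter), is known and the 3,5-difluorophenyl is a different pattern. Compound 4 is thus estimated at 45000 nM in this assay, with a range of 15000 nM to 130000 nM.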

Compound 4, half-maximal inhibitory concentration: > 100000 nM
Compound 4: no number, only a limit (the forecaster's own chance of this, stated with the estimate: 25%); middle value at least 2.2-fold (0.34 log units) away from the limit.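

Where the two fluorines sit on the phenyl at this position matters in this assay, which compound 3 alone could not show: 3,5-difluorophenyl in place of 2,4-difluorophenyl gives an at least 3.0-fold higher number from compound 3 to compound 4 (0.47 log units; beyond the scatter). A difluorophenyl in place of 4-phenylphenyl therefore does not by itself lower the number, as this replacement gives an at least 1.1-fold higher number from compound 1 to compound 4 (0.05 log units; that floor lies within the scatter), a floor set by the limit that compound 4 gives rather than a number. The step between the 4-(trifluoromethyl)phenyl of compound 2 and the 3,5-difluorophenyl of compound 4 cannot be read, because both values are limits: the limit of > 100000 nM in this assay, at which 2 of the 4 values shown sit.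

From the compounds shown here alone, how far compound 4 lies beyond its limit remains open. Also open, going by these compounds, is how this position would respond to a phenyl carrying an amine or a carboxylic acid, or to a longer chain on the oxygen.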